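The source may hold more compounds than are shown below. What is called first, only, known or untested is meant among the compounds shown, and "the series" means these compounds.

Working notes on the series

Three compounds of the series have numbers in a functional assay on MDA-MB-231 cells (Homo sapiens) for inhibition, read by MTT assay, with a stated time of 72 h; a lower number here means a stronger inhibitor, a higher number a weaker inhibitor. Compound 1 `O=C(CSc1nc(Nc2ccccc2)c2ccccc2n1)Nc1ccccc1Cl` gives 24400 nM; compound 3 `O=C(CSc1nc(Nc2ccccc2)c2ccccc2n1)Nc1ccc(F)c(Cl)c1` gives 21600 nM; compound 2 `C=CC(=O)Nc1cccc(NC(=O)CSc2nc(Nc3ccccc3)c3ccccc3n2)c1` gives 10200 nM, the lowest number of the three, and its steps to both neighbours are beyond the scatter. Those steps are a 2.4-fold lower number from compound 1 to compound 2 (0.38 log units; beyond the scatter) and, from the other side, a 2.1-fold higher number from compound 2 to compound 3 (0.33 log units; beyond the scatter), both modest, while compound 1 and compound 3 sit within the scatter of each other, a 1.1-fold lower number from compound 1 to compound 3 (0.05 log units; within the scatter). Every measured step changes the aryl group on the amide-type nitrogen; none changes the group on the nitrogen on the aromatic ring of the shared core.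

Compound 4 `C=CC(=O)Nc1cccc(NC(=O)CSc2nc(Nc3ccc(Cl)cc3Cl)c3ccccc3n2)c1` differs from compound 2 in exactly that untested place: 2,4-dichlorophenyl in place of phenyl on a nitrogen on an aromatic ring. For the measured compounds named here, no measured step bears on this change, so the three steps give only the spread of numbers seen so far, and nothing indicates a direction for a change at this nitrogen. The step from compound 2 is therefore expected to be small, a 1.2-fold higher number from compound 2 to compound 4 (0.07 log units; within the scatter), with the direction open. Compound 4 is expected to give 12000 nM in this assay, within a range from 5000 nM to 30000 nM.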

Compound 4, half-maximal inhibitory concentration: 23100 nM
Estimate against measurement, compound 4: 1.9-fold (0.28 log units) below, within the range that was stated.
By their numbers in this assay, from the lowest: compound 2; then compounds 3, 4 and 1 (each within the scatter of the next).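

In this assay, for the compounds shown here, the group on the nitrogen on an aromatic ring of the shared core proves able to move the number, with a 2.3-fold higher number from compound 2 to compound 4 (0.36 log units; beyond the scatter) as the first measured step at this place. With the 3-((vinylcarbonyl)amino)phenyl group held constant on the amide-type nitrogen, 2,4-dichlorophenyl in place of phenyl gives a weaker inhibitor, so this nitrogen is not a silent position, and the step is modest, as are the steps beyond the scatter on the amide-type nitrogen. No measurement at hand accounts for this step.

This single step adds both chlorine atoms at once, so it leaves open whether one chlorine alone would give a step of this size, and whether the same change would give a similar step with the 2-chlorophenyl or 3-chloro-4-fluorophenyl group on the amide-type nitrogen. Also open, on these data alone, is how this nitrogen would respond to a group of another kind, such as a cyclohexyl ring or a phenyl ring carrying a carboxylic acid, and whether any group here would give a lower number than phenyl.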